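This account rests on a few compounds, and the source may have more. Where it says the series, first, only, none or still open, it means among the compounds named here.

Of the compounds shown here, three with a shared core have been tested in an ADME assay on MT4 cells (Homo sapiens) for cytotoxicity, read by MTT assay; on this read-out higher numbers stand for lower toxicity in this test and lower numbers for higher toxicity in this test. Compound 1 `Cc1cccc(C(=O)N(C(=S)OCCN2C(=O)c3ccccc3C2=O)c2ccc(Cl)cc2)c1` gives 58000 nM. Compound 2 `O=C1c2ccccc2C(=O)N1CCOC(=S)N(C(=O)c1cccnc1Cl)c1ccc(Br)cc1` returns only a limit, > 100000 nM. Compound 3 `Cc1ccc(N(C(=O)c2cccc(C)c2)C(=S)OCCN2C(=O)c3ccccc3C2=O)cc1` also returns only a limit, > 100000 nM. Compound 3 therefore stands at the limit of > 100000 nM in this assay, at which 2 of the 3 values shown sit.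

Compound 4 `Cc1ccc(N(C(=O)c2cc(F)cc(F)c2)C(=S)OCCN2C(=O)c3ccccc3C2=O)cc1` has 3,5-difluorophenyl in place of 3-methylphenyl on a carbonyl carbon, with 3,5-difluorophenyl in place of 3-methylphenyl on a carbonyl carbon. For the measured compounds named here, no measured step makes this change. Going by the values given here, the one measured step, an at least 1.7-fold higher number from compound 1 to compound 3 (0.23 log units; that floor lies within the scatter), puts methyl in place of chloro on an aromatic carbon, so it bears on the new change only indirectly. It offers no direction for the new change, and no step beyond the scatter is expected in this assay. The expected change is an at least 1.1-fold lower number from compound 3 to compound 4 (0.04 log units; that floor lies within the scatter). The estimate for compound 4 is 90000 nM, with an expected range of 35000 nM to 200000 nM.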

Compound 4, half-maximal cytotoxic concentration: 54000 nM
The estimate for compound 4 lay 1.7-fold (0.22 log units) above the measured number; the measured number falls inside the stated range.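

Putting 3,5-difluorophenyl in place of 3-methylphenyl on a carbonyl carbon gives, in this assay, an at least 1.8-fold lower number from compound 3 to compound 4 (0.26 log units; that floor lies within the scatter), the first step read at this position, as the earlier step put methyl in place of chloro on an aromatic carbon. Compound 4 gives a number, 54000 nM, not a limit. The step can be stated only as a floor, because compound 3 stands at a limit: the limit of > 100000 nM in this assay, at which 2 of the 4 values shown sit.

The compounds shown leave open how large the true gap is and whether it lies beyond the scatter. They also leave open how a single fluorine, or a 3-aminophenyl or 3-carboxyphenyl group, would read on the same carbonyl carbon.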